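Arylpiperazine Amides at the Alpha-1 Receptor: Toward Compound 4

This account rests on a few compounds, and the source may have more. Where it says the series, first, only, none or still open, it means among the compounds named here.

Three measured compounds share a core joined through a chain to an amide or imide. Compound 1 `COc1ccc(OC)c(N2CCN(CCCCN3C(=O)c4ccccc4C3=O)CC2)c1` gives 15 nM in an assay on frontal cortex for binding affinity to Adrenergic receptor alpha-1 (Rattus norvegicus), read by radioligand binding; a higher number here means a weaker inhibitor, a lower number a stronger inhibitor. Among the measured compounds shown here, compound 2 `O=C1c2ccccc2C(=O)N1CCCCN1CCN(c2ccccc2[N+](=O)[O-])CC1` gives 25 nM in this assay; the only single-point step among the measured set, a 1.7-fold higher number from compound 1 to compound 2 (0.22 log units; within the scatter), concerns the ring on an amine nitrogen in a ring and stays within the scatter. Compound 3 `COc1ccccc1N1CCN(CCCCNC(=O)c2ccc(I)cc2)CC1` gives 15 nM in this assay, level with compound 1 at the digits shown and together with it the lowest of the three numbers; against compound 2 it differs only within the scatter.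

Compound 4 `COc1ccccc1N1CCN(CCCCNC(=O)CCCc2ccccc2)CC1` differs from compound 3 in one place: 3-phenylpropyl in place of 4-iodophenyl on a carbonyl carbon. For the measured compounds named here, no measured step touches this position; the one known step, a 1.7-fold higher number from compound 1 to compound 2 (0.22 log units; within the scatter), changes a different part of the molecule and was small. Nothing beyond the scatter is available to extrapolate from, so only a modest step is expected, a 1.7-fold higher number from compound 3 to compound 4 (0.22 log units; within the scatter) in this assay, leaning toward a somewhat higher number. Compound 4 is estimated at 25 nM in this assay, with a range from 8 nM to 80 nM.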

Compound 4, inhibition constant: 84 nM
For compound 4 the middle estimate is 3.4-fold (0.53 log units) below the measured one, outside the stated range (above it).
By their numbers in this assay, from the lowest: compounds 1, 3 and 2 (each within the scatter of the next); then compound 4.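

In this assay, among the compounds shown here, the group on a carbonyl carbon whose other neighbours are an amide-type nitrogen proves able to move the number: a 5.6-fold higher number from compound 3 to compound 4 (0.75 log units; beyond the scatter), whereas the only earlier step, made at the ring on an amine nitrogen in a ring, stayed within the scatter. The change is also more telling than its counted features suggest, since 4-iodophenyl and 3-phenylpropyl each carry one six-membered aromatic ring of carbon only, no hydrogen-bond donors or acceptors and no net charge, and differ in the count only by 7 heavy atoms against 9, with iodine present only in the group that leaves. Nothing presented here accounts for why this exchange raises the number.

The compounds shown do not tell whether the step follows the loss of the iodine or the arrival of the three-carbon chain, a question that an unsubstituted phenyl, a 4-chlorophenyl or a 2-phenylethyl on the same carbonyl carbon would address. They also leave open whether 3-phenylpropyl would give a similar step on a compound carrying the 2,5-dimethoxyphenyl or 2-nitrophenyl group.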